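A few compounds are considered here, and "the series" means these few. Any claim that something is new, unique, unknown or untested is made for them only; others in the source may bear on it.

Measured compounds in an ADME assay on liver (Homo sapiens) for metabolic stability, using microsomes; on this read-out higher numbers stand for a longer-lived compound and lower numbers for a shorter-lived compound:
Compound 1, `CN1Cc2cc(ccc2S(=O)(=O)C2CC2)NC(=O)CCc2cc(ccc2C2CC2)[C@@H](Nc2ccc3c(N)ncc(F)c3c2)C1=O`: 0.433 h
Compound 2, `COc1ccc2cc1CCC(=O)Nc1ccc(S(=O)(=O)C3CC3)c(c1)CN(C)C(=O)[C@@H]2Nc1ccc2c(N)ncc(F)c2c1`: 0.233 h

Within the data shown here, compound 2 stands at the lower of the two numbers, with compound 1 nearest; the single step between them, a 1.9-fold lower number from compound 1 to compound 2 (0.27 log units; within the scatter), lies within the scatter, so the two compounds are not separated on this read-out.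

Compound 3, `COc1c(F)cc2cc1CCC(=O)Nc1ccc(S(=O)(=O)C3CC3)c(c1)CN(C)C(=O)[C@@H]2Nc1ccc2c(N)ncc(F)c2c1`, differs from compound 2 by fluoro in place of hydrogen on an aromatic carbon. Among the measured compounds shown here, no measured step exchanges hydrogen for fluoro, so nothing bears directly on this change. The only step available, the exchange of cyclopropyl for methoxy described above, stayed within the scatter, and a single fluorine added on an aromatic carbon gives no grounds to expect more. The expected step of a 1.1-fold higher number from compound 2 to compound 3 (0.03 log units; within the scatter) is therefore none beyond the scatter, in either direction. Compound 3 is estimated at 0.25 h in this assay, with a range of 0.12 h to 0.5 h.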

Compound 3, half-life: 0.233 h
Estimate against measurement, compound 3: 1.1-fold (0.03 log units) above, within the range that was stated.
By their numbers in this assay, from the lowest: compounds 2, 3 and 1 (each within the scatter of the next).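

In this assay, fluoro in place of hydrogen on an aromatic carbon ortho to a methoxy group gives no change at the digits printed from compound 2 to compound 3 (within the scatter) on this read-out. Among these compounds, this is the first reading at this position: the earlier pair covered only the exchange of cyclopropyl for methoxy, whereas this step shows that a single fluorine on this carbon does not separate the two compounds. The data at hand offer no explanation for this outcome.

On these data alone, whether chloro, a nitrile or an amine on the same carbon would give a step beyond the scatter remains open. Also open, as far as these compounds go, is whether fluoro on this carbon would read the same with cyclopropyl in place of the methoxy group, as in compound 1.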